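Trifluoromethyl Added: Cytotoxicity Expected to Stay Out of Reach

The source may hold more compounds than are shown below. What is called first, only, known or untested is meant among the compounds shown, and "the series" means these compounds.

Compound 1 `CN(CC(=O)N1CCN(c2ccccc2)CC1)C(=O)c1ccc(S(C)(=O)=O)c([N+](=O)[O-])c1` was examined in an ADME assay on HepG2 cells (Homo sapiens) for cytotoxicity, read by CellTiter-Glo and ATP content, with a stated time of 72 h; on this read-out lower numbers stand for an effect already at smaller amounts and higher numbers for an effect only at larger amounts of compound. Compound 1 reaches only the limit of this assay, > 27000 nM, which is a bound and not a number. Compound 2 `Cc1ccc(N2CCN(C(=O)C3CCN(C(=O)c4ccc(S(C)(=O)=O)c([N+](=O)[O-])c4)CC3)CC2)cc1` likewise gives only a limit in this assay, > 27000 nM. Compound 3 `CS(=O)(=O)c1ccc(C(=O)NCC(=O)N2CCc3ccccc3C2)cc1[N+](=O)[O-]` also stops at a limit, > 27000 nM. So compound 1 stands where every measured value sits: the limit of > 27000 nM in this assay, at which 3 of the 3 values shown sit. Compound 4 `CN(CC(=O)N1CCN(c2ccc(C(F)(F)F)cc2)CC1)C(=O)c1ccc(S(C)(=O)=O)c([N+](=O)[O-])c1` differs from compound 1 by trifluoromethyl in place of hydrogen on an aromatic carbon. For the measured compounds named here, no pair of measured compounds differs in one place, so no measured step exists. In this assay the expected step from compound 1 to compound 4 is a number no higher from compound 1 to compound 4 (the limit leaves the size open), none beyond the scatter. The estimate for compound 4 is 27000 nM, from 9000 nM to 80000 nM, most likely again only a limit.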

Compound 4, half-maximal effective concentration: 11900 nM
For compound 4 the middle estimate is 2.3-fold (0.36 log units) above the measured one; the range from low to high includes it.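

In this assay, trifluoromethyl in place of hydrogen on this aromatic carbon gives an at least 2.2-fold lower number from compound 1 to compound 4 (0.35 log units; beyond the scatter), so a change at this position can bring an effect within the range of the assay. Compound 4 is the only compound shown that gives a number and not a limit: the limit of > 27000 nM in this assay, at which 3 of the 4 values shown sit.

On these data alone, the full size of the step remains unknown, as the value for compound 1 is only a limit. Also open, as far as these compounds go, is whether another group at this place, such as chlorine or a carboxylic acid, would lower the number too.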